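Piperidine in Place of Amino: Expected Half-Life Shift

A few compounds are considered here, and "the series" means these few. Any claim that something is new, unique, unknown or untested is made for them only; others in the source may bear on it.

Of the compounds shown here, three have been measured. Compound 1 `CC(C)(C)Cn1ccnc1/N=C(/Nc1ccc(Cl)c(Cl)c1)NC(C)(C)C` and compound 2 `CC(C)N/C(=N\c1nccn1Cc1ccccc1)Nc1ccc(Cl)c(Cl)c1` carry different substituents on their shared core. In an in vitro ADME assay on microsomes from liver (Homo sapiens) for metabolic stability, read by LC-MS, tested at 1 uM (on this read-out higher numbers stand for a longer-lived compound and lower numbers for a shorter-lived compound), compound 1 gives 0.202 h, and in this assay compound 2 gives 0.267 h; these two values lie within the usual scatter of each other. Compound 3 `CC(C)N1CCN=C1/N=C(\N)Nc1ccc(Cl)c(Cl)c1` has a smaller substitution pattern on the same core. In this assay compound 3 gives > 1 h, which is a limit of the assay and not a number. Compound 3 thus stands at the limit of > 1 h in this assay, at which 1 of the 3 values shown sits, and its true half-life is known only to lie past that point.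

Compound 4 `CC(C)N1CCN=C1/N=C(/Nc1ccc(Cl)c(Cl)c1)N1CCCCC1` is not yet measured. Relative to compound 3 it carries piperidin-1-yl in place of amino on a carbon with a double bond to nitrogen, piperidin-1-yl in place of amino on a carbon with a double bond to nitrogen. For the measured compounds named here, no measured pair in this set differs by this single change, so the step has no direct precedent here. The step from compound 3 to compound 4 in this assay is expected to go downward beyond the scatter, an at least 2.2-fold lower number from compound 3 to compound 4 (0.34 log units; beyond the scatter), since the two measured compounds with larger groups on the core sit well under the limit. Compound 4 is accordingly estimated at 0.45 h, with a range from 0.18 h to 1.2 h.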

Compound 4, half-life: > 1 h
Compound 4: a limit, no number; the forecaster's own chance of this, stated with the estimate: 25%; middle value at least 2.2-fold (0.34 log units) away from the limit.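

Compound 4, like compound 3, gives a limit and not a number in this assay, so no step between the two can be read: the limit of > 1 h in this assay, at which 2 of the 4 values shown sit.

The compounds shown leave open how far the half-life of each lies past that limit, and so whether piperidin-1-yl in place of amino changes it at all.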